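A few compounds are considered here, and "the series" means these few. Any claim that something is new, unique, unknown or untested is made for them only; others in the source may bear on it.

Compound 1 `Cn1c(=O)c(C(=O)NCCCCCCN)c(O)c2ccccc21` and compound 2 `Cn1c(=O)c(C(=O)Nc2ccc(N)cc2)c(O)c2ccccc21` share a core and differ only at the amide-type nitrogen. In a functional assay on the whole organism (strain Fischer 344) for inhibition, with Rattus norvegicus as the target, read by paw edema, at a dose of 0.01 mmol/kg by the intraperitoneal route (on this read-out lower numbers stand for less inhibition and higher numbers for more inhibition at the one dose given (going by the name of the read-out)), compound 1 gives 68.5%, and compound 2 gives 69.5%. Compound 1 thus stands lowest of the two numbers measured, yet its nearest neighbour is only a number 1 percentage points higher from compound 1 to compound 2 (within the scatter), so no real order between them can be read. Compound 3 `Cn1c(=O)c(C(=O)NCCCCCCNC(=O)CCCCC2CCSS2)c(O)c2ccccc21` is not yet measured in this assay. It differs from compound 1 by a group of 11 heavy atoms (8 carbon, 1 oxygen, 2 sulfur; one five-membered non-aromatic ring with 2 hetero atoms) in place of a hydrogen atom, on an amine nitrogen. Within the data shown here, the one measured step that bears on this change is the swap at the amide-type nitrogen, and that step was within the scatter, so the group added in compound 3 is expected to shift the number little. The estimate for compound 3 is a number 6.5 percentage points lower from compound 1 to compound 3 (within the scatter), giving an expected inhibition of 62% with a range from 45% to 78%.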

Compound 3, a percentage reported as inhibition, in the whole organism at one dose (the size of the read-out at that dose, not a potency): 53%
Beside the measured number, compound 3's estimate is 9 percentage points above it, within the range that was stated.
By their numbers in this assay, from the lowest: compound 3; then compounds 1 and 2 (each within the scatter of the next).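

In this assay, the amine nitrogen on the chain proves to be a place where a change can register: a group of 11 heavy atoms, with its five-membered ring holding two sulfur atoms, in place of a hydrogen atom gives a number 15.5 percentage points lower from compound 1 to compound 3 (beyond the scatter). Among these compounds, the earlier swap at the amide-type nitrogen stayed within the scatter, so this is the first step that the read-out clearly separates. Even so, compound 3 keeps an inhibition of 53% at this dose, and nothing measured here says what lies behind the lower number.

As far as these compounds go, it remains open whether the lower number goes with the sulfur ring or simply with a carbonyl on this nitrogen, a question that an acetyl group there could help to settle. Also open, from the compounds shown here alone, is whether the same group on the amine of compound 2 would give a similar step.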